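The source may hold more compounds than are shown below. What is called first, only, known or untested is meant among the compounds shown, and "the series" means these compounds.

In an ADME assay on BJ cells (Homo sapiens) for cytotoxicity, read by luminescence, with a stated time of 72 h (a lower number here means that less compound is needed, a higher number that more compound is needed for the effect), compound 1, `C=Cc1cccc(-c2[nH]c3cc(OC)ccc3c(=O)c2C(=O)OCC)c1`, gives > 21500 nM, which is a limit of the assay and not a number. Compound 2, `CCOC(=O)c1c(-c2cccc(-c3ccccc3)c2)[nH]c2cc(OC)ccc2c1=O`, gives > 21500 nM, again a limit. Compound 3, `CCCCOc1cccc(-c2[nH]c3cc(OC)ccc3c(=O)c2C(=O)OCC)c1`, stands at > 21500 nM, also only a limit, so its place in this assay is bounded on one side and not fixed.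

Compound 4, `CCOC(=O)c1c(-c2cccc(OCC(C)C)c2)[nH]c2cc(OC)ccc2c1=O`, has the same atoms as compound 3, joined differently: isopropyl in place of propyl on a saturated chain carbon bound to an oxygen on an aromatic ring. Butoxy thus becomes isobutoxy.

The measured steps that bear on this change are those that alter the same substituent: a step that the two limits leave unreadable from compound 1 to compound 2, a step that the two limits leave unreadable from compound 1 to compound 3 and a step that the two limits leave unreadable from compound 2 to compound 3. Due to the limit of > 21500 nM in this assay, at which 3 of the 3 values shown sit, none of them has a readable size, and they give no sign of a direction. No step beyond the usual scatter is therefore expected in this assay. The expected step is a step that the limit leaves unreadable from compound 3 to compound 4.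

Compound 4 is estimated at 22000 nM, with an expected range of 10000 nM to 40000 nM, and the assay will most likely report only a limit.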

Compound 4, half-maximal effective concentration: > 21500 nM
Compound 4: only a limit was reported (the forecaster's own chance of this, stated with the estimate: 90%); the middle value does not contradict the limit.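

In this assay compound 4 gives > 21500 nM, a limit of the assay and not a number. The steps to compound 4 from compound 1, compound 2 and compound 3 cannot be read, due to a shared limit: the limit of > 21500 nM in this assay, at which 4 of the 4 values shown sit.

The compounds shown leave open whether changing this substituent alters the value at all, and in which direction.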